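The compounds below may be only part of what the source reports. "The series", "measured", "known", "first", "only" and "open" are said of these compounds alone.

Two analogues that share one core have been measured. Compound 1 `C=C1[C@@H](OC(C)=O)C[C@@H]2[C@](C)(CO[Si](C)(C)C(C)(C)C)[C@H](OC(C)=O)CC[C@@]2(C)[C@@H]1C[C@@H](Nc1ccccc1)C1=CCOC1=O` carries a phenyl group on the amine nitrogen; in a functional assay on MCF7 cells (Homo sapiens) for cytotoxicity, read by sulforhodamine B assay (on this read-out lower numbers stand for stronger inhibition and higher numbers for weaker inhibition), compound 1 gives 4840 nM. Compound 2 `C=C1[C@@H](OC(C)=O)C[C@@H]2[C@](C)(CO[Si](C)(C)C(C)(C)C)[C@H](OC(C)=O)CC[C@@]2(C)[C@@H]1C[C@@H](Nc1cccc2ccccc12)C1=CCOC1=O` carries naphthalen-1-yl in that place, and in this assay compound 2 gives 5770 nM. Among the measured compounds shown here, the single step between them, a 1.2-fold higher number from compound 1 to compound 2 (0.08 log units; within the scatter), lies within the scatter, so on these numbers compound 2 cannot be set apart from compound 1; it simply stands as the second of two indistinguishable points.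

Compound 3 `C=C1[C@@H](OC(C)=O)C[C@@H]2[C@](C)(CO[Si](C)(C)C(C)(C)C)[C@H](OC(C)=O)CC[C@@]2(C)[C@@H]1C[C@@H](Nc1ccc(F)cc1)C1=CCOC1=O` has not been measured. It differs from compound 2 as follows: 4-fluorophenyl in place of naphthalen-1-yl on an amine nitrogen. For the measured compounds named here, the only measured step that bears on this exchange is a 1.2-fold higher number from compound 1 to compound 2 (0.08 log units; within the scatter), a swap at the same amine nitrogen that produced nothing beyond the scatter. Since compound 1, with 4840 nM, carries the plain phenyl group, putting 4-fluorophenyl back in place of naphthalen-1-yl is expected to leave the number where it is. The step estimated in this assay is a 1.2-fold lower number from compound 2 to compound 3 (0.06 log units; within the scatter). Compound 3 is therefore expected to give about 5000 nM in this assay, within a range from 2500 nM to 10000 nM.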

Compound 3, half-maximal inhibitory concentration: 4340 nM
For compound 3 the middle estimate is 1.2-fold (0.06 log units) above the measured one; the measured number falls inside the stated range.
By their numbers in this assay, from the lowest: compounds 3, 1 and 2 (each within the scatter of the next).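

Replacing the fused naphthalen-1-yl with a single substituted ring gives a 1.3-fold lower number from compound 2 to compound 3 (0.12 log units; within the scatter), so a second exchange at this amine nitrogen, this time with a different ring count and a halogen, also stays inside the scatter in this assay. Among the compounds shown here, the compounds also offer the first look at a substituent on the phenyl ring itself: fluoro in place of hydrogen on an aromatic carbon gives a 1.1-fold lower number from compound 1 to compound 3 (0.05 log units; within the scatter), and that small change cannot be told apart from no change at all. Phenyl, naphthalen-1-yl and 4-fluorophenyl therefore form a flat set of three on this read-out, and nothing shown offers any explanation for this flatness.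

Still open, from the compounds shown here alone, is whether any aryl group is needed on this nitrogen, since all three compounds carry one and none has a benzyl group, a cyclohexyl group or a simple alkyl chain there. Going by these compounds, it is equally open whether a group of a different kind on the phenyl ring, such as a carboxylic acid or an amine, would move the number beyond the scatter.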